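The source may hold more compounds than are shown below. What is called first, only, known or untested is meant among the compounds shown, and "the series" means these compounds.

Among the compounds with values here, two measured compounds define the series so far. Compound 1 `CCC(=O)NC1CCCN(C(C)=O)C1` carries an acetyl on the ring nitrogen of its core and gives 1 mg/kg in a functional assay on the whole organism with Mus musculus as the target, with a stated time of 30 min; a higher number here means that more compound is needed for the effect, a lower number that less compound is needed. Compound 2 `CCC(=O)NCC1CCN(C(=O)c2ccccc2)CC1` carries a benzoyl on the ring nitrogen and a (propanoylamino)methyl on a saturated ring carbon; in this assay compound 2 gives 1 mg/kg, level with compound 1 at the digits recorded, the two lying within the usual scatter of each other. Within the data shown here, no pair of measured compounds differs in a single place, so no measured step is available to calibrate the next change.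

Compound 3 `CCC(=O)NC1CCN(C(=O)c2ccccc2)CC1` is the next member and differs from compound 2 in one place: propanoylamino in place of (propanoylamino)methyl on a saturated ring carbon. The chain that links the amide to the ring is shortened while the benzoyl on the ring nitrogen is kept. Among the measured compounds shown here, with no measured step to lean on, and with compound 2 already at 1 mg/kg, the expectation for the step from compound 2 to compound 3 is none beyond the scatter, no change at the digits printed from compound 2 to compound 3 (within the scatter). For compound 3 the estimate in this assay is 1 mg/kg, with a range from 0.3 mg/kg to 3 mg/kg.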

Compound 3, minimum effective dose: 0.1 mg/kg
The estimate for compound 3 lay 10-fold (1.00 log units) above the measured number, and the stated range ends above it.
By their numbers in this assay, from the lowest: compound 3; then compounds 1 and 2 (each within the scatter of the next).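

In this assay, the series now has its first measured single-place step: propanoylamino in place of (propanoylamino)methyl on a saturated ring carbon gives a 10-fold lower number from compound 2 to compound 3 (1.00 log units; beyond the scatter). Within the data shown here, with the benzoyl on the ring nitrogen kept, this shows that the position three ring bonds from the ring nitrogen responds to the link between the amide and the ring, which could not be read before, as no earlier pair differed in one place only. Nothing measured on these compounds accounts for the step.

This single step leaves open whether the trend continues in the other direction with a longer chain between the amide and the ring, and whether the direct attachment of compound 3 is the best link at this position. Also open, going by these compounds, are how a free amine or a carboxylic acid would read in place of the propanoylamino on this ring carbon, and whether the shorter link gives a comparable step when an acetyl replaces the benzoyl on the ring nitrogen.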